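Aryl swap on the shared core: outlook for compound 3

A few compounds are considered here, and "the series" means these few. Any claim that something is new, unique, unknown or untested is made for them only; others in the source may bear on it.

Compound 1 `CC(C)(C)Cc1c(-c2ccccn2)sc(N)c1C(=O)c1ccc(Cl)cc1` carries a pyridin-2-yl group and in an assay on CHO cells for displacement of a labelled ligand from adenosine receptor A3 (Homo sapiens), read by scintillation counting, tested at 10 uM (a lower number here means less inhibition, a higher number more inhibition at the concentration tested (going by the name of the read-out)), compound 1 gives 1%. Compound 2 `CC(C)(C)Cc1c(-c2cc(F)ccc2F)sc(N)c1C(=O)c1ccc(Cl)cc1` carries 2,5-difluorophenyl in its place, and in this assay compound 2 gives 1%. For the measured compounds named here, the single measured step, no change at the digits printed from compound 1 to compound 2 (within the scatter), is flat. On the numbers shown, compound 2 therefore stands level with compound 1; neither can be called the stronger.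

Compound 3 `COc1cccc(-c2sc(N)c(C(=O)c3ccc(Cl)cc3)c2CC(C)(C)C)c1` is the next variant in the same place. The change from compound 2 is 3-methoxyphenyl in place of 2,5-difluorophenyl on an aromatic carbon. Going by the values given here, only one measured step bears on this position, no change at the digits printed from compound 1 to compound 2 (within the scatter), and it shows that exchanging a pyridin-2-yl for a 2,5-difluorophenyl left inhibition essentially at the floor. With both measured compounds near the bottom of the read-out, a third aryl at the same place is expected to give a number 2 percentage points higher from compound 2 to compound 3 (within the scatter), that is, no step beyond the scatter. Compound 3 is accordingly estimated at 3%, with a range from -5% to 15%; a clear rise would go against the pattern set by compound 1 and compound 2.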

Compound 3, a percentage reported as inhibition, at one concentration (the size of the read-out at that concentration, not a potency): 1%
The estimate for compound 3 lay 2 percentage points above the measured number, within the range that was stated.
By their numbers in this assay, from the lowest: compounds 1, 2 and 3 (each within the scatter of the next).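

Working notes on the aryl position: in this assay the exchange of 2,5-difluorophenyl for 3-methoxyphenyl gives no change at the digits printed from compound 2 to compound 3 (within the scatter) and the exchange of pyridin-2-yl for 3-methoxyphenyl gives no change at the digits printed from compound 1 to compound 3 (within the scatter) on the same aromatic carbon of the shared core. The flat read now extends to a third aryl group and to a substituent with one hydrogen-bond acceptor in place of a group with none, at an equal count of heavy atoms, so across compounds 1, 2 and 3 the choice among these six-membered aromatic rings, next to the ring sulfur, does not separate the compounds, and none of the three goes against this. No supporting measurement accounts for this flat read.

Still open, from the compounds shown here alone, is whether a group of another kind at this carbon, such as an aminomethyl group, a carboxylic acid or a longer alkyl chain, would move the read-out off its present level. Also open, going by these compounds, is whether replacing the neopentyl group or the (4-chlorophenyl)carbonyl group would make the aryl position respond at all.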